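A few compounds are considered here, and "the series" means these few. Any claim that something is new, unique, unknown or untested is made for them only; others in the source may bear on it.

Three compounds that share one core and differ in the group on a carbonyl carbon have numbers in a functional assay on A20 cells (Mus musculus) for inhibition, with stated times of 1 h, 16 h and 24 h; on this read-out higher numbers stand for weaker inhibition and lower numbers for stronger inhibition. Compound 1 `N#CC1(NC(=O)[C@@H]2C[C@@H](S(=O)(=O)c3ccccc3)C[C@H]2C(=O)N2CCOCC2)CC1` gives 12 nM. Compound 2 `N#CC1(NC(=O)[C@@H]2C[C@@H](S(=O)(=O)c3ccccc3)C[C@H]2C(=O)N2CC3CCC(C2)O3)CC1` gives 16 nM. Compound 3 `N#CC1(NC(=O)[C@@H]2C[C@@H](S(=O)(=O)c3ccccc3)C[C@H]2C(=O)N2CC3(COC3)C2)CC1` gives 248 nM, the highest number of the three and so the weakest inhibition, with its steps to both others beyond the scatter.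

Compound 4 `CC1CCN(C(=O)[C@@H]2C[C@H](S(=O)(=O)c3ccccc3)C[C@H]2C(=O)NC2(C#N)CC2)CC1` is still unmeasured. It carries 4-methylpiperidin-1-yl in place of the group of compound 3, a change counted as a group of 7 heavy atoms (6 carbon, 1 nitrogen; one six-membered non-aromatic ring with 1 hetero atom) in place of a group of 7 heavy atoms (5 carbon, 1 nitrogen, 1 oxygen; 2 four-membered non-aromatic rings with 1 hetero atom each), on a carbonyl carbon.

Among the measured compounds shown here, three measured steps bear on this. The step of a 1.3-fold higher number from compound 1 to compound 2 (0.12 log units; within the scatter) lies within the scatter, while a 21-fold higher number from compound 1 to compound 3 (1.32 log units; beyond the scatter) and a 16-fold higher number from compound 2 to compound 3 (1.19 log units; beyond the scatter) are both large. Among these compounds, only the group with two four-membered rings gives a high number. Compound 4 gives up those rings for a six-membered ring, and compound 1, at 12 nM, also has a six-membered ring there. For the measured compounds named here, no measured step shows what the missing ring oxygen of compound 4 does, so the range stays wide.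

The expected change in this assay is a large one toward stronger inhibition, slightly smaller than the measured steps, estimated as a 9.9-fold lower number from compound 3 to compound 4 (1.00 log units; beyond the scatter). For compound 4 the estimated value is 25 nM, with an expected range from 8 nM to 90 nM.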

Compound 4, half-maximal inhibitory concentration: 2 nM
Beside the measured number, compound 4's estimate is 13-fold (1.10 log units) above it; the whole stated range lies above it.
By their numbers in this assay, from the lowest: compound 4; then compounds 1 and 2 (each within the scatter of the next); then compound 3.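

The readings in this assay show that this position on the carbonyl carbon tolerates a group with no ring oxygen, and that such a group can do better than both oxygen-bearing six-membered options: 4-methylpiperidin-1-yl in place of morpholin-4-yl gives (a 6.0-fold lower number from compound 1 to compound 4 (0.78 log units; beyond the scatter)), and the comparison with the bridged group of compound 2 gives (an 8.0-fold lower number from compound 2 to compound 4 (0.90 log units; beyond the scatter)). Both steps are modest but beyond the scatter, so compound 4 is the strongest inhibitor of the four, and the earlier plateau shared by compounds 1 and 2 is not the limit at this position. The full span the position covers has also widened, with the step from the group with two four-membered rings now large (a 120-fold lower number from compound 3 to compound 4 (2.09 log units; beyond the scatter)), and no measurement here gives a reason for any of these differences.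

The step from compound 1 changes the ring oxygen and adds the methyl at once, so the shares of the two changes cannot be separated. Plain piperidin-1-yl would divide them, and 4-ethylpiperidin-1-yl would show whether a longer chain in place of the methyl goes further still.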